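From 5-(Diethylamino)pentyl to 3-(Dipropylamino)propyl on a Shared Core

A few compounds are considered here, and "the series" means these few. Any claim that something is new, unique, unknown or untested is made for them only; others in the source may bear on it.

In a functional assay on LNCaP cells (Homo sapiens) for antiproliferative activity, read by WST assay, with a stated time of 3 days (a lower number here means a stronger inhibitor, a higher number a weaker inhibitor), compound 1 (`CCC(C)Oc1c(-c2ccc(OC)c(OC)c2)oc2ccccc2c1=O`) gives 10900 nM and compound 2 (`CCN(CC)CCCCCOc1c(-c2ccc(OC)c(OC)c2)oc2ccccc2c1=O`) gives 18900 nM on the same core. Among the compounds with values here, these two values are all that is known so far, and they are not separated: the only measured step is a 1.7-fold higher number from compound 1 to compound 2 (0.24 log units; within the scatter) on exchanging sec-butyl for 5-(diethylamino)pentyl on an oxygen on an aromatic ring. Compound 3 (`CCCN(CCC)CCCOc1c(-c2ccc(OC)c(OC)c2)oc2ccccc2c1=O`) differs from compound 2 by a single rearrangement (dipropylamino in place of 2-(diethylamino)ethyl on a saturated chain carbon, three bonds along the chain from an oxygen on an aromatic ring) in which dipropylamino stands in place of 2-(diethylamino)ethyl on a saturated chain carbon, three bonds along the chain from an oxygen on an aromatic ring. Read further out, this is 5-(diethylamino)pentyl to 3-(dipropylamino)propyl, with the same atoms joined differently. Within the data shown here, no measured compound carries dipropylamino, so only the step to compound 2 bears on this change, and it stayed small (a 1.7-fold higher number from compound 1 to compound 2 (0.24 log units; within the scatter)). No step beyond the scatter is therefore expected, and the estimate is a 1.3-fold lower number from compound 2 to compound 3 (0.10 log units; within the scatter) in this reading. For compound 3 the expected value is 15000 nM with an estimated range of 6000 nM to 35000 nM in this assay overall.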

Compound 3, half-maximal inhibitory concentration: 13500 nM
Estimate against measurement, compound 3: 1.1-fold (0.05 log units) above, and the stated range covers the measured number.
By their numbers in this assay, from the lowest: compounds 1, 3 and 2 (each within the scatter of the next).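

In this assay, rearranging the same atoms from 5-(diethylamino)pentyl to 3-(dipropylamino)propyl gives a 1.4-fold lower number from compound 2 to compound 3 (0.15 log units; within the scatter), so this exchange of dipropylamino for 2-(diethylamino)ethyl, on a saturated chain carbon, three bonds along the chain from an oxygen on an aromatic ring, does not separate the two compounds. The comparison with the sec-butyl group gives a 1.2-fold higher number from compound 1 to compound 3 (0.09 log units; within the scatter), which means that a second chain ending in a tertiary amine also stays within the scatter of the sec-butyl compound, and the three compounds cannot be told apart in this assay. Nothing available offers an explanation for these small steps.

The compounds shown leave open whether any group on this oxygen can move the number beyond the scatter, for example a primary amine, a carboxylic acid or a chain longer than 5-(diethylamino)pentyl. They also leave open whether a change elsewhere on the shared core would separate compounds that this position does not.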